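Dropping a 3-methylbut-2-en-1-yl group: effect on cytotoxicity

This account rests on a few compounds, and the source may have more. Where it says the series, first, only, none or still open, it means among the compounds named here.

Compound 1 `COc1cc(OC)c(C(=O)/C=C/c2ccc(N3CCN(C(=O)OC(C)(C)C)CC3)cc2)c(O)c1CC=C(C)C` — > 100000 nM
Compound 2 `COc1cc(O)c(C(=O)/C=C/c2ccc(N3CCN(C(=O)OC(C)(C)C)CC3)cc2)c(OC)c1` — 47300 nM
Compound 3 `COc1cc(OC)c(C(=O)/C=C/c2cccc(N3CCN(C(=O)OC(C)(C)C)CC3)c2)c(O)c1CC=C(C)C` — 42600 nM

All three compounds were tested in an ADME assay on MCF7-DOX cells (Homo sapiens) for cytotoxicity, read by MTT assay, with a stated time of 48 h; a lower number here means a stronger inhibitor, a higher number a weaker inhibitor. For compound 1 the result is a limit of the assay rather than a number: the limit of > 100000 nM in this assay, at which 1 of the 3 values shown sits. The change from compound 1 to compound 2, (hydrogen in place of 3-methylbut-2-en-1-yl on an aromatic carbon), gives an at least 2.1-fold lower number from compound 1 to compound 2 (0.32 log units; beyond the scatter). Compound 3 is built from the same atoms as compound 1 but joined differently; the difference between the two cores is not broken down here.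

Compound 4 `COc1cc(O)c(C(=O)/C=C/c2cccc(N3CCN(C(=O)OC(C)(C)C)CC3)c2)c(OC)c1` has not yet been measured in this assay. It arises from compound 3 by the same change, (hydrogen in place of 3-methylbut-2-en-1-yl on an aromatic carbon), with the surroundings of the place described in the same words as before. Because the earlier step of an at least 2.1-fold lower number from compound 1 to compound 2 (0.32 log units; beyond the scatter) is only a lower bound, its true size is uncertain, and I expect the step of a 1.9-fold lower number from compound 3 to compound 4 (0.29 log units; within the scatter) to be of a similar kind. Resting on the value of compound 3, 42600 nM, my estimate for compound 4 is 22000 nM, expected to fall between 8000 nM and 60000 nM.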

Compound 4, half-maximal inhibitory concentration: 56700 nM
The estimate for compound 4 lay 2.6-fold (0.41 log units) below the measured number; low and high end bracket the measured number.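

On the second core, taking away the 3-methylbut-2-en-1-yl group in this assay gives a 1.3-fold higher number from compound 3 to compound 4 (0.12 log units; within the scatter), so the removal brings no change beyond the scatter here. The same change therefore did not carry over as the same step from one core to the other, and the two results are further apart than repeat measurements would explain: the same change on two cores in this assay, an at least 2.1-fold lower number (0.32 log units; beyond the scatter) from compound 1 to compound 2 and a 1.3-fold higher number (0.12 log units; within the scatter) from compound 3 to compound 4, at least 2.8-fold (0.44 log units) apart, beyond the scatter of two such steps. This does not show the true size of the earlier step or why the cores behave differently, since compound 1 carries a limit of the assay rather than a number: the limit of > 100000 nM in this assay, at which 1 of the 4 values shown sits.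

The compounds shown leave open what a shorter chain such as a methyl group, or a longer chain than 3-methylbut-2-en-1-yl, would do on the same aromatic carbon of each core. They also leave open whether an amine at that carbon would give the same result on both cores, and whether a third core would side with either of these two.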